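Thiazoline in Place of Imidazole on a Benzyl Thioether

The compounds below may be only part of what the source reports. "The series", "measured", "known", "first", "only" and "open" are said of these compounds alone.

Of the compounds shown here, two have so far been measured in an assay on isolated protein for inhibition of Indoleamine 2,3-dioxygenase 1 (Homo sapiens), with a stated time of 60 min, tested at 10 uM; on this read-out higher numbers stand for more inhibition at the one concentration tested (going by the name of the read-out) and lower numbers for less inhibition. Compound 1 `Clc1ccc2sc(SCc3ccccc3CCc3ccccc3)nc2c1` gives 9%. Compound 2 `c1ccc(CCc2ccccc2CSc2ncc[nH]2)cc1` gives 19%, the higher of the two numbers, but compound 1 sits only a little lower and the two values fall within the usual scatter of each other, so no order can be read between them. Compound 3 `c1ccc(CCc2ccccc2CSC2=NCCS2)cc1` has not yet been tested. Among the measured compounds shown here, it differs from compound 2 in one place: a group of 5 heavy atoms (3 carbon, 1 nitrogen, 1 sulfur; one five-membered non-aromatic ring with 2 hetero atoms) in place of a group of 5 heavy atoms (3 carbon, 2 nitrogen; one five-membered aromatic ring with 2 hetero atoms), on a sulfur No step between measured compounds is available as a guide, and neither measured value is far from the bottom of the scale. The step from compound 2 to compound 3 is therefore expected to be small, a number 4 percentage points lower from compound 2 to compound 3 (within the scatter), a change not beyond the scatter. For compound 3 the estimate in this assay is 15%, with a range from 0% to 35%.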

Compound 3, a percentage reported as inhibition, at one concentration (the size of the read-out at that concentration, not a potency): 0%
Compound 3: middle estimate off by 15 percentage points, on the high side; the measured number falls inside the stated range.
By their numbers in this assay, from the lowest: compounds 3, 1 and 2 (each within the scatter of the next, the first and the last beyond it).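

In this assay, the exchange on the sulfur whose other neighbour is a saturated chain carbon gives a number 19 percentage points lower from compound 2 to compound 3 (beyond the scatter), the first step read at this position. It shows that this place responds to the ring it carries, even though both groups have 5 heavy atoms and no net charge; the entering five-membered non-aromatic ring has 0 hydrogen-bond donors and 2 acceptors, where 1H-imidazol-2-yl has 1 of each. No measured property bears on this step, so nothing here accounts for it.

An imidazoline ring or a thiazole ring on the same sulfur would help separate the loss of the aromatic ring from the exchange of nitrogen for sulfur. Going by these compounds, whether the same exchange gives a similar step on another core remains open.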